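A few compounds are considered here, and "the series" means these few. Any claim that something is new, unique, unknown or untested is made for them only; others in the source may bear on it.

Compound 1 `ClCc1cccc(Cn2cnc3ncnc(Cl)c32)c1` and compound 3 `ClCc1cccc(Cn2cnc3nc(Cl)nc(Cl)c32)c1` share one core, while compound 2 `ClCc1ccccc1Cn1cnc2ncnc(Cl)c21` has the same atoms joined differently; the difference between the two cores is not broken down here. In a functional assay on EKVX cells (Homo sapiens) for cytotoxicity, read by sulforhodamine B assay, with a stated time of 48 h (a lower number here means that less compound is tolerated, a higher number that more compound is tolerated), compound 1 gives 64600 nM, compound 2 gives 45700 nM and compound 3 gives 4570 nM. The change from compound 1 to compound 3 is chloro in place of hydrogen on an aromatic carbon, and it made a step of a 14-fold lower number from compound 1 to compound 3 (1.15 log units; beyond the scatter). Compound 4 `ClCc1ccccc1Cn1cnc2nc(Cl)nc(Cl)c21` has not yet been measured; it differs from compound 2 by chloro in place of hydrogen on an aromatic carbon, the same change at the same place. Because the step of a 14-fold lower number from compound 1 to compound 3 (1.15 log units; beyond the scatter) was large, compound 4 is expected to show a step of similar size, a 14-fold lower number from compound 2 to compound 4 (1.14 log units; beyond the scatter). Compound 4 is thus estimated at 3300 nM, expected to lie between 1400 nM and 8000 nM.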

Compound 4, concentration lethal to 50% of the cells: 6020 nM
For compound 4 the middle estimate is 1.8-fold (0.26 log units) below the measured one, within the range that was stated.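

In this assay, chloro in place of hydrogen on the second core gave a 7.6-fold lower number from compound 2 to compound 4 (0.88 log units; beyond the scatter) and so moved the number the same way as on the first core. The two steps agree in size as far as repeated measurements of this kind can tell: the same change on two cores in this assay, a 14-fold lower number (1.15 log units; beyond the scatter) from compound 1 to compound 3 and a 7.6-fold lower number (0.88 log units; beyond the scatter) from compound 2 to compound 4, 1.9-fold (0.27 log units) apart, within the scatter of two such steps. This rests on two pairs of compounds only, so it does not show that the step would hold on any other core, and it does not explain why the number drops.

The compounds shown leave open whether an amine or a methoxy group on that same aromatic carbon, between two ring nitrogen atoms, would act as chloro does. They also leave open what a hydroxymethyl group would do in place of the chloromethyl group.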